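The source may report more compounds than this note shows. Statements on the series, on what has been measured and on what is new or still open speak of the compounds shown alone.

Of the compounds shown here, two carry numbers so far. In an in vitro functional assay on cells for antagonist activity at 5-hydroxytryptamine receptor 1D (Homo sapiens) (on this read-out higher numbers stand for weaker inhibition and lower numbers for stronger inhibition), compound 1 `NC(=O)c1ccc2c(c1)CCO[C@H]2CCN1CCN(c2ccc3cc(F)ccc3c2)CC1` gives 0.86 nM. Compound 2 `C[C@H]1CN(c2cccc3cc(F)ccc23)CCN1CC[C@@H]1OCc2cc(C(N)=O)ccc21` gives 0.05 nM in this assay, the lower of the two numbers; the nearest is compound 1, whose number sits beyond the scatter of repeat measurements. Going by the values given here, no pair of measured compounds differs in a single place, so nothing here tells directly how much a change in configuration alone moves this assay. Compound 3 `C[C@H]1CN(c2cccc3cc(F)ccc23)CCN1CC[C@H]1OCc2cc(C(N)=O)ccc21` is the next to be measured. Relative to compound 2, (the two compounds have the same atoms and bonds and differ only in configuration as drawn: 1 of 2 stereo elements differ; a stereocentre at a saturated ring carbon is drawn S in compound 2 and R in compound 3). The number for compound 2, 0.05 nM, leaves more room upward than downward. On that basis the step from compound 2 to compound 3 is expected to be a 6.0-fold higher number from compound 2 to compound 3 (0.78 log units; beyond the scatter) in this assay, a move toward a higher number. Compound 3 is therefore expected to give 0.3 nM in this assay, within a range from 0.05 nM to 2 nM.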

Compound 3, antagonist equilibrium constant: 1.9 nM
The estimate for compound 3 lay 6.3-fold (0.80 log units) below the measured number; the measured number falls inside the stated range.
By their numbers in this assay, from the lowest: compound 2; then compound 1; then compound 3.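

In this assay, the series now has its first step that differs in one place only: inverting the stereocentre at the saturated ring carbon from S to R gives a 38-fold higher number from compound 2 to compound 3 (1.58 log units; beyond the scatter). This step is large and lies beyond the scatter, so configuration at this single carbon is enough on its own to move the number substantially, with S the favoured form in this pair. The whole step can be assigned to that centre, with no change in substituents contributing, because of the following: the fact that compounds 2 and 3 differ only in the configuration as drawn

The compounds shown leave open whether S stays favoured on other scaffolds in the series, such as the core of compound 1, or when the other stereo element is inverted. They also leave open how the same inversion behaves when a carboxylic acid replaces the amide or a longer chain replaces the linker.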